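The compounds below may be only part of what the source reports. "The series", "measured", "known", "first", "only" and "open" are said of these compounds alone.

Compound 1 `CCCCNC(=O)C1CCN(c2nc(N)c3cc(OC)c(OC)cc3n2)CC1`, compound 2 `CCCNC(=O)CC1CCN(c2nc(N)c3cc(OC)c(OC)cc3n2)CC1` and compound 3 `COc1cc2nc(N3CCC(CC(=O)NCC4CC4)CC3)nc(N)c2cc1OC` share one core and differ only in the group carried on a saturated ring carbon. In an assay on isolated protein for displacement of a labelled ligand from Adrenergic receptor alpha-1 (Rattus norvegicus) (a higher number here means a weaker inhibitor, a lower number a stronger inhibitor), compound 1 gives 0.67 nM, compound 2 gives 0.65 nM and compound 3 gives 1.08 nM. Compound 1 sits second highest of the three numbers; its nearest neighbour is compound 2, with a 1.0-fold lower number from compound 1 to compound 2 (0.01 log units; within the scatter), and its furthest is compound 3, with a 1.6-fold higher number from compound 1 to compound 3 (0.21 log units; within the scatter). Compound 4 `CCCCNC(=O)COC1CCN(c2nc(N)c3cc(OC)c(OC)cc3n2)CC1` has not yet been measured; it differs from compound 1 by (butylcarbamoyl)methoxy in place of butylcarbamoyl on a saturated ring carbon. Among the compounds with values here, two measured steps bear on this change: a 1.0-fold lower number from compound 1 to compound 2 (0.01 log units; within the scatter), where (propylcarbamoyl)methyl stands in place of butylcarbamoyl, and a 1.6-fold higher number from compound 1 to compound 3 (0.21 log units; within the scatter), where ((cyclopropylmethyl)carbamoyl)methyl stands in place of butylcarbamoyl; both keep the number within the scatter. Within the data shown here, no measured step introduces a methoxy link, so a larger shift cannot be excluded, but on these steps the expectation is a small change, and a 1.3-fold higher number from compound 1 to compound 4 (0.13 log units; within the scatter) is estimated. Compound 4 is therefore expected to give 0.9 nM in this assay, between 0.3 nM and 3 nM.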

Compound 4, inhibition constant: 0.79 nM
Compound 4: middle estimate off by 1.1-fold (0.06 log units), on the high side; low and high end bracket the measured number.
By their numbers in this assay, from the lowest: compounds 2, 1, 4 and 3 (each within the scatter of the next).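

With the methoxy link added, the longer (butylcarbamoyl)methoxy group keeps the number in this assay within the scatter of butylcarbamoyl (a 1.2-fold higher number from compound 1 to compound 4 (0.07 log units; within the scatter)). The same holds against the two groups carrying a methyl link (a 1.2-fold higher number from compound 2 to compound 4 (0.08 log units; within the scatter)) and (a 1.4-fold lower number from compound 3 to compound 4 (0.14 log units; within the scatter)), so at this saturated ring carbon, three ring bonds from the ring nitrogen, none of the four groups shown separates from the others. No measurement shown offers an explanation for this flat result.

The compounds shown leave open whether the number stays this flat when a carboxylic acid or an amine replaces the amide, or when a much longer chain replaces the butyl group. They also leave open whether the amide hydrogen is needed at all, which a tertiary amide such as an N,N-dimethyl amide would address.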